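Furan-2-yl in Place of a Diethylamino Side Chain

The compounds below may be only part of what the source reports. "The series", "measured", "known", "first", "only" and "open" are said of these compounds alone.

compound 1, `CC(C)CC/N=C(\NC#N)Nc1cccnc1`: 20 mg/kg
compound 2, `CCC(C)/N=C(\NC#N)Nc1cccnc1`: 20 mg/kg
compound 3, `CCN(CC)CC/N=C(\NC#N)Nc1cccnc1`: > 8 mg/kg

In a functional assay on the whole organism (blood, strain Wistar-Okamoto) with Rattus norvegicus as the target, with a stated time of 5 days (on this read-out higher numbers stand for an effect only at larger amounts of compound and lower numbers for an effect already at smaller amounts), compound 1 and compound 2 sit at the same value, and the step of no change at the digits printed from compound 1 to compound 2 (within the scatter) stays within the scatter. For compound 3 the assay gives only a limit, (the limit of > 8 mg/kg in this assay, at which 1 of the 3 values shown sits), and no number. The step that the limit leaves unreadable from compound 1 to compound 3 therefore cannot be sized, and compound 3 stands only as a limit.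

Compound 4, `N#CN/C(=N\Cc1ccco1)Nc1cccnc1`, differs from compound 3 by furan-2-yl in place of (diethylamino)methyl on a saturated chain carbon bound to a double-bonded nitrogen. For the measured compounds named here, the one measured step that touches this part of the chain is the unreadable one from compound 1 to compound 3, so the data give no sized precedent for the change. Compound 4 is expected near the values of compound 1 and compound 2, at 20 mg/kg, within 8 mg/kg to 50 mg/kg. The step that the limit leaves unreadable from compound 3 to compound 4 is thus the expectation, read against a limit.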

Compound 4, minimum effective dose: 20 mg/kg
Compound 4: middle estimate and measured number agree at the digits printed, and the stated range covers the measured number.
By their numbers in this assay, from the lowest: compounds 1, 2 and 4 (each within the scatter of the next).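

In this assay, for the compounds shown here, the five-membered aromatic ring of compound 4 is the first ring in this part of the chain, and the (furan-2-yl)methyl group on the double-bonded nitrogen gives no change at the digits printed from compound 2 to compound 4 (within the scatter), while the isobutyl comparison gives no change at the digits printed from compound 1 to compound 4 (within the scatter). Among these three compounds, the read-out therefore does not separate the furan-2-yl group from the open alkyl chains. The steps involving compound 3 cannot be read, since compound 3 stands only as a limit: the limit of > 8 mg/kg in this assay, at which 1 of the 4 values shown sits.

As far as these compounds go, how a phenyl ring, a longer chain or a carboxylic acid at this place would read in this assay remains open. So does whether a number for compound 3 would set its diethylamino chain apart.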